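This account rests on a few compounds, and the source may have more. Where it says the series, first, only, none or still open, it means among the compounds named here.

Of the compounds shown here, two of a shared core have been tested in an assay on CHO cells for displacement of a labelled ligand from adenosine receptor A1 (Homo sapiens), read by scintillation counting, with a stated time of 3 h; a higher number here means a weaker inhibitor, a lower number a stronger inhibitor. Compound 1, `Cn1c(-c2ccccc2)nc2c(NC3CCCCC3)ncnc21`, gives 5.7 nM in this assay. Compound 2, `CCCn1c(-c2ccccc2)nc2c(NC3CCCC3)ncnc21`, gives 10 nM in this assay, the higher of the two numbers, though its gap to compound 1 lies within the scatter. Compound 3, `CCCn1c(-c2ccccc2)nc2c(NC3CCCCC3)ncnc21`, is not yet measured; it differs from compound 2 by cyclohexyl in place of cyclopentyl on a nitrogen on an aromatic ring. Compound 1 already carries a cyclohexyl group and gives 5.7 nM in this assay, so no step beyond the scatter is expected here. Compound 3 is therefore estimated at 6 nM, within 2.5 nM to 15 nM, which would mean an expected step of a 1.7-fold lower number from compound 2 to compound 3 (0.22 log units; within the scatter).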

Compound 3, inhibition constant: 27 nM
Estimate against measurement, compound 3: 4.5-fold (0.65 log units) below; the measured number lies above the stated range.
By their numbers in this assay, from the lowest: compounds 1 and 2 (each within the scatter of the next); then compound 3.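

In this assay, among the compounds shown here, cyclohexyl in place of cyclopentyl on a nitrogen on an aromatic ring gives a 2.7-fold higher number from compound 2 to compound 3 (0.43 log units; beyond the scatter) as the first reading of this change alone, since compounds 1 and 2 differ in two places. With cyclohexyl held fixed, ethyl in place of hydrogen on a saturated chain carbon bound to an aromatic nitrogen gives a 4.7-fold higher number from compound 1 to compound 3 (0.68 log units; beyond the scatter) as a second step beyond the scatter. Nothing available explains either step. Still open, going by these compounds, is how a cyclobutyl or phenyl group on that nitrogen, or a longer chain such as butyl on the aromatic nitrogen, would read.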